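This account rests on a few compounds, and the source may have more. Where it says the series, first, only, none or still open, it means among the compounds named here.

Measured so far in an assay on isolated protein (Cricetulus griseus) for binding affinity to Alpha-1B adrenergic receptor (Mesocricetus auratus), read by radioligand binding; a lower number here means a stronger inhibitor, a higher number a weaker inhibitor:

- compound 1, `CCS(=O)(=O)Nc1cc(C2CCCCC2)cc2c1CCCC2c1c[nH]cn1`: 891 nM
- compound 2, `CS(=O)(=O)Nc1ccc(O)c2c1CCCC2c1c[nH]cn1`: < 10000 nM

Compound 1 is the only one of the two with a definite number in this assay, and compound 1 gives 891 nM. For compound 2 the reading is a limit of the assay rather than a number, namely < 10000 nM. Going by the values given here, this is the situation described by the limit of < 10000 nM in this assay, at which 1 of the 2 values shown sits, so where compound 2 truly stands within that range is not known, and no step between the two measured compounds can be drawn, since they differ in more than one place.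

Compound 3, `CS(=O)(=O)Nc1ccc(Cl)c2c1CCCC2c1c[nH]cn1`, is the next one to be measured in this assay. It is made from compound 2 by the change (chloro in place of hydroxy on an aromatic carbon), that is, chloro in place of hydroxy on an aromatic carbon. Among the compounds with values here, no measured pair shows what this exchange does here, so the expectation rests only on the loose bounds already seen. The step from compound 2 to compound 3 is expected to be a step that the limit leaves unreadable from compound 2 to compound 3, which is to say no clear movement beyond the scatter is anticipated in either direction. On that basis compound 3 is estimated at 3000 nM in this assay, with a range from 500 nM to 15000 nM.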

Compound 3, inhibition constant: < 10000 nM
Compound 3 was reported as a limit; the forecaster's own chance of this, stated with the estimate: 30%; the middle value lies beyond the limit too.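

In this assay, compound 2 and compound 3 are both reported only as limits of the assay, not as numbers, so no step can be read for chloro in place of hydroxy on an aromatic carbon: the limit of < 10000 nM in this assay, at which 2 of the 3 values shown sit.

The compounds shown leave open where compound 2 and compound 3 truly stand, and whether this exchange shifts the value at all.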